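Series notes: from compound 3 to compound 4

The compounds below may be only part of what the source reports. "The series", "measured", "known", "first", "only" and "open" are said of these compounds alone.

Among the measured compounds shown here, compound 1 (`Nc1ccc(-c2cn([C@@H]3CN[C@H](C(=O)Nc4ccc(Cl)c(C(F)(F)F)c4)C3)nn2)cn1`) reads 25200 nM in a functional assay on K562/Adr cells (Homo sapiens) for inhibition, read by MTT assay, with a stated time of 48 h (on this read-out higher numbers stand for weaker inhibition and lower numbers for stronger inhibition), and holds the lowest number so far. Compound 2 (`C=CC(=O)Nc1ccc(-c2cn([C@@H]3CN[C@H](C(=O)Nc4ccc(Cl)c(C(F)(F)F)c4)C3)nn2)cn1`) reads 80400 nM in this assay and lies in the middle. Compound 3 (`O=C(NC1CC1)c1cncc(-c2cn([C@@H]3CN[C@H](C(=O)Nc4ccc(Cl)c(C(F)(F)F)c4)C3)nn2)c1`) reads 175000 nM in this assay and holds the highest of the three numbers, which makes it the weakest inhibitor measured.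

Compound 4 (`Nc1nc2ccc(-c3cn([C@@H]4CN[C@H](C(=O)Nc5ccc(Cl)c(C(F)(F)F)c5)C4)nn3)nc2s1`) differs from compound 3 by one exchange (a group of 10 heavy atoms (6 carbon, 3 nitrogen, 1 sulfur; one five-membered aromatic ring with 2 hetero atoms, one six-membered aromatic ring with 1 hetero atom) in place of a group of 12 heavy atoms (9 carbon, 2 nitrogen, 1 oxygen; one three-membered non-aromatic ring of carbon only, one six-membered aromatic ring with 1 hetero atom), on an aromatic carbon) on an aromatic carbon of the five-membered aromatic ring with 3 nitrogen. For the measured compounds named here, its entering group has no three-membered non-aromatic ring of carbon only, and no measured compound carries it.

Two measured steps exchange the group at this place: a 6.9-fold higher number from compound 1 to compound 3 (0.84 log units; beyond the scatter) and a 2.2-fold higher number from compound 2 to compound 3 (0.34 log units; beyond the scatter) are both modest, and they lead to the expectation that compound 4 falls back from compound 3 by a similar size. The remaining step of a 3.2-fold higher number from compound 1 to compound 2 (0.50 log units; beyond the scatter) only adds vinylcarbonyl on a nitrogen and bears on this exchange less directly. With so few groups seen, the expectation is loose.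

A step of a 3.9-fold lower number from compound 3 to compound 4 (0.59 log units; beyond the scatter) is therefore expected in this assay and points towards stronger inhibition. For compound 4 the estimated value is 45000 nM with an expected range from 15000 nM to 130000 nM in this assay as a working figure.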

Compound 4, half-maximal inhibitory concentration: 187000 nM
Compound 4: the middle estimate sits 4.2-fold (0.62 log units) below what was measured; the measured number lies above the stated range.
By their numbers in this assay, from the lowest: compound 1; then compound 2; then compounds 3 and 4 (each within the scatter of the next).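

In this assay, a 1.1-fold higher number from compound 3 to compound 4 (0.03 log units; within the scatter) shows that two differently built groups on this aromatic carbon of the five-membered aromatic ring with 3 nitrogen can read alike: 5-(cyclopropylcarbamoyl)pyridin-3-yl and the entering group, with its five-membered aromatic ring with 2 hetero atoms and its six-membered aromatic ring with 1 hetero atom, cannot be told apart here. Against the other two groups, the entering group gives a 2.3-fold higher number from compound 2 to compound 4 (0.37 log units; beyond the scatter) and a 7.4-fold higher number from compound 1 to compound 4 (0.87 log units; beyond the scatter) so compound 1, with 6-aminopyridin-3-yl, stays the strongest inhibitor of the four, and a second group now joins 5-(cyclopropylcarbamoyl)pyridin-3-yl at the weak end of the series. The information at hand offers no measurement that would explain these readings.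

The compounds shown leave open whether an aromatic ring at this place is needed at all, which a short aminoalkyl chain or a carboxylic acid on the same carbon could test. They also leave open whether the gap in favour of compound 1 rests on its free amine, which a hydroxyl or a methoxy group on the same pyridine would help to separate.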